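The source may hold more compounds than are shown below. What is called first, only, known or untested is meant among the compounds shown, and "the series" means these compounds.

Working notes on the sulfonyl-containing series. Compound 1 `N=S1(=O)c2ccccc2C(=O)N1c1ccccc1` was run in an ADME assay on a cell-free system (plasma, Homo sapiens) for protein binding (on this read-out lower numbers stand for a smaller free fraction and higher numbers for a larger free fraction), where compound 1 is recorded as "not determined" (no result reported), so it adds nothing to the comparison. Among the compounds with values here, compound 2 `NC1=NS(=O)(=O)c2ccccc21` therefore stands alone with a number: in this assay compound 2 gives 0.48, and with only one measured value there is no ranking to speak of.

The step of interest leads to compound 3 `O=S1(=O)N=C(Nc2ccccc2)c2ccccc21`. The structural change is phenyl in place of hydrogen on an amine nitrogen. Within the data shown here, no measured pair in the set shows what this change does to the unbound fraction, so the expectation rests on the change itself. A drop in the free fraction is expected, and the step from compound 2 to compound 3 is expected to be a 4.8-fold lower number from compound 2 to compound 3 (0.68 log units; beyond the scatter), a move beyond the scatter rather than within it. In this assay compound 3 is estimated at 0.1, with a plausible range from 0.04 to 0.25.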

Compound 3, unbound fraction in the plasma assay: 0.16
Estimate against measurement, compound 3: 1.6-fold (0.20 log units) below; measured number inside the range.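

Within the data shown here, on the amine nitrogen, phenyl in place of hydrogen gives the first readable step in the plasma assay, a 3.0-fold lower number from compound 2 to compound 3 (0.48 log units; beyond the scatter), so the free fraction responds to a change at this position. In a physicochemical assay for lipophilicity, at pH 7.4 (a higher number here means a more lipophilic compound, a lower number a more polar compound), compound 2 gives 0.2 and compound 3 gives 2. The lower free fraction of compound 3 may go with its higher lipophilicity, although a single pair cannot establish the link: the measured distribution coefficient of compound 2, 0.2, and of compound 3, 2, a number 1.80 log units higher (beyond the scatter)

From the compounds shown here alone, whether the two read-outs move together beyond this one pair remains open. Methyl on the same amine nitrogen, or a phenyl carrying a carboxylic acid, would test whether the unbound fraction follows the distribution coefficient or depends on the aromatic ring itself.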